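The compounds below may be only part of what the source reports. "The series", "measured", "known", "first", "only" and "open" are said of these compounds alone.

Measured so far:
compound 1 `CC1CCN(C2CCN(S(=O)(=O)c3cccc(Br)c3)CC2)CC1`: 3.2 nM in a functional assay on DLD-1 cells (Homo sapiens) for antiproliferative activity, read by CellTiter-Glo, with a stated time of 72 h; on this read-out lower numbers stand for stronger inhibition and higher numbers for weaker inhibition
compound 2 `CC1CCN(C2CCN(S(=O)(=O)c3cn(C)cn3)CC2)CC1`: > 5000 nM, a limit of the assay
compound 3 `CC1CCN(C2CCN(S(=O)(=O)c3cccnc3Cl)CC2)CC1`: > 5000 nM, a limit of the assay

Among the measured compounds shown here, compound 1 carries the only number in this assay; the other two values are limits, as the limit of > 5000 nM in this assay, at which 2 of the 3 values shown sit, states. The steps of an at least 1500-fold higher number from compound 1 to compound 2 (3.19 log units; beyond the scatter) and an at least 1500-fold higher number from compound 1 to compound 3 (3.19 log units; beyond the scatter) each exchange the whole 3-bromophenyl on the sulfonyl sulfur for another aromatic ring, and both run to the limit. The step that the two limits leave unreadable from compound 2 to compound 3 cannot be read, since it lies between two limits.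

Compound 4 `COc1ccc(-c2cccc(S(=O)(=O)N3CCC(N4CCC(C)CC4)CC3)c2)cc1` keeps the ring of compound 1 and differs from it by 4-methoxyphenyl in place of bromo on an aromatic carbon. For the measured compounds named here, none of the measured steps tests a change of this kind: in them the ring itself is replaced, whereas here the ring stays and one group on it is exchanged for a larger one. The measured steps show only that the aryl on the sulfonyl sulfur decides the activity of compound 1, so the outcome in this assay is uncertain. A modest step toward a higher number of about a 3.8-fold higher number from compound 1 to compound 4 (0.57 log units; beyond the scatter) is expected. Compound 4 is therefore estimated at 12 nM, with a range from 2 nM to 80 nM.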

Compound 4, half-maximal inhibitory concentration: 23 nM
The estimate for compound 4 lay 1.9-fold (0.28 log units) below the measured number; measured number inside the range.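

The place on the six-membered aromatic ring of carbon only, meta to a large group, accepts a much larger group than bromo and keeps a measured number: in this assay, 4-methoxyphenyl with its 8 heavy atoms and added aromatic ring gives a 7.2-fold higher number from compound 1 to compound 4 (0.86 log units; beyond the scatter). The exchange costs activity beyond the scatter, yet the step is modest, so a change on the retained ring behaves differently from the two replacements of the whole ring. Compounds 2 and 3, which carry those replaced rings, remain limits of the assay and not numbers: the limit of > 5000 nM in this assay, at which 2 of the 4 values shown sit.

Among the compounds shown here, the single step does not tell whether the added ring, the methoxy group or the larger number of heavy atoms accounts for the change, and it gives no trend at this place. Also open, from the compounds shown here alone, is whether a methyl, a dimethylamino group or a carboxylic acid at this place would stay close to compound 1 or move toward the limit of the assay, and whether 4-methoxyphenyl would be accepted elsewhere on the ring.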